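Swapping an aryl group on the pyridine core for an indole

A few compounds are considered here, and "the series" means these few. Any claim that something is new, unique, unknown or untested is made for them only; others in the source may bear on it.

Measured compounds in an ADME assay (liver) for metabolic stability, with Liver microsome (Homo sapiens) as the target, using microsomes and NADPH, with a stated time of 30 min, tested at 1 uM; a higher number here means faster removal of the compound, a lower number slower removal:
- compound 1 `Cn1cc(-c2cc(C(O)(C(F)(F)F)C(F)(F)F)cnc2N2CCN(S(=O)(=O)c3ccc(N)nc3)CC2)cn1`: 19 mL.min-1.g-1
- compound 2 `CC(C)n1cc(-c2cc(C(O)(C(F)(F)F)C(F)(F)F)cnc2N2CCN(S(=O)(=O)c3ccc(N)nc3)CC2)cn1`: 38 mL.min-1.g-1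
- compound 3 `Cc1ccc(-c2cc(C(O)(C(F)(F)F)C(F)(F)F)cnc2N2CCN(S(=O)(=O)c3ccc(N)nc3)CC2)cn1`: 43 mL.min-1.g-1

Compound 3 has the highest number of the three, though compound 2 sits within the scatter of it, as the step of a 1.1-fold higher number from compound 2 to compound 3 (0.05 log units; within the scatter) shows; only compound 1 is clearly lower, by a 2.3-fold higher number from compound 1 to compound 3 (0.35 log units; beyond the scatter). Between compound 1 and compound 2 the step of a 2.0-fold higher number from compound 1 to compound 2 (0.30 log units; within the scatter) is within the scatter.

Compound 4 `Nc1ccc(S(=O)(=O)N2CCN(c3ncc(C(O)(C(F)(F)F)C(F)(F)F)cc3-c3cc4ccccc4[nH]3)CC2)cn1` differs from compound 3 in one place: 1H-indol-2-yl in place of 6-methylpyridin-3-yl on an aromatic carbon. Among the measured compounds shown here, none of the measured steps swaps in a group like 1H-indol-2-yl, so the earlier steps give only indirect guidance. They do show that changing the group on this aromatic carbon moves the number by at most a modest amount, as in a 2.3-fold higher number from compound 1 to compound 3 (0.35 log units; beyond the scatter). The expected step is therefore a small rise, a 1.4-fold higher number from compound 3 to compound 4 (0.14 log units; within the scatter), with wide uncertainty. Compound 4 is estimated at 60 mL.min-1.g-1, with a range from 30 mL.min-1.g-1 to 120 mL.min-1.g-1.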

Compound 4, intrinsic clearance in microsomes: < 14 mL.min-1.g-1
Compound 4: a limit, no number (the forecaster's own chance of this, stated with the estimate: 3%); middle value at least 4.2-fold (0.63 log units) away from the limit.
By their numbers in this assay, from the lowest: compounds 1, 2 and 3 (each within the scatter of the next, the first and the last beyond it). At a limit, below all of these: compound 4.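

Compound 4 gives no number in this assay, only a limit: the limit of < 14 mL.min-1.g-1 in this assay, at which 1 of the 4 values shown sits. Until now, no change on this aromatic carbon had brought the number below that of compound 1, whereas 1H-indol-2-yl gives clearly slower removal than the two groups it is compared with here, as an at least 3.0-fold lower number from compound 3 to compound 4 (0.48 log units; beyond the scatter) and an at least 2.7-fold lower number from compound 2 to compound 4 (0.43 log units; beyond the scatter) show. Against compound 1 the picture is less certain, since an at least 1.3-fold lower number from compound 1 to compound 4 (0.13 log units; that floor lies within the scatter) means that the printed limit alone does not set compound 4 clearly apart from compound 1.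

On these data alone, how far the true value of compound 4 lies under its limit remains open. Also open, as far as these compounds go, is which part of 1H-indol-2-yl matters, which a 1-methylindol-2-yl group, with a methyl on the indole nitrogen, or a pyrrol-2-yl group, without the six-membered ring, could begin to separate.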